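A trifluoromethyl group on the benzyl ring of compound 1

The source may hold more compounds than are shown below. What is called first, only, known or untested is meant among the compounds shown, and "the series" means these compounds.

Compound 1 `Nc1nc(NCc2ccccc2)nc(-c2ccccc2CO)n1` is a member of a small set of aminotriazines measured in a functional assay on cells for positive allosteric modulation of G-protein coupled receptor 68 (Homo sapiens), read by a luciferase reporter and cAMP accumulation, with a stated time of 30 min, at pH 6.8 and pH 8.3, in the presence of a further agent that is not named here; a lower number here means a less potent compound, a higher number a more potent compound, by a factor of ten per unit of this negative logarithm. In this assay compound 1 gives 4.35. For the measured compounds named here, compound 3 `Nc1nc(NCc2ccccc2)nc(-c2cc(F)ccc2CO)n1` carries fluoro in place of hydrogen on an aromatic carbon of the hydroxymethyl-bearing ring, and in this assay compound 3 gives 4.58; the step of a number 0.23 log units higher from compound 1 to compound 3 (within the scatter), so compound 1 and compound 3 lie within the scatter of each other, and compound 1 stands at one end of only two numbers. Compound 2 `Cc1ccccc1-c1nc(N)nc(NCc2ccccc2)n1`, which has methyl in place of the hydroxymethyl group, is reported in this assay as "not active" (no number reported), with no number given.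

Compound 4 `Nc1nc(NCc2cccc(C(F)(F)F)c2)nc(-c2ccccc2CO)n1` differs from compound 1 as follows: trifluoromethyl in place of hydrogen on an aromatic carbon. Going by the values given here, none of the measured steps touches the benzyl ring, so no step bears directly on this change; the only measured step, a number 0.23 log units higher from compound 1 to compound 3 (within the scatter), was within the scatter and concerned the other ring. In the absence of guidance, the author expects compound 4 to stay close to compound 1, with a step of a number 0.10 log units higher from compound 1 to compound 4 (within the scatter) that is not expected to exceed the scatter in either direction. The author's estimate for compound 4 in this assay is therefore 4.45, with a range from 3.95 to 4.95.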

Compound 4, negative logarithm of the antagonist equilibrium constant: 5.11
Beside the measured number, compound 4's estimate is 0.66 log units below it, outside the stated range (above it).
By their numbers in this assay, from the lowest: compounds 1 and 3 (each within the scatter of the next); then compound 4.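

Putting trifluoromethyl on an aromatic carbon of the benzyl ring where compound 1 has hydrogen, meta to a large group, moves the number in this assay beyond the scatter, with a number 0.76 log units higher from compound 1 to compound 4 (beyond the scatter). For the compounds shown here, the earlier fluoro change on the other ring, with a number 0.23 log units higher from compound 1 to compound 3 (within the scatter), had not done so, and no earlier step touched the benzyl ring at all, so this is the first sign that the ring can take a substituent of four heavy atoms with a modest gain rather than a loss. Nothing measured here accounts for the gain, which rests on this single pair of compounds.

As far as these compounds go, it remains open whether the step belongs to trifluoromethyl itself or would also appear with a chlorine atom, a methyl group or a methoxy group at this place, and whether the same group would give a similar step elsewhere on the benzyl ring. Also unresolved is whether this step would add to the fluoro change on the other ring if both stood in one compound, and how an amine or a carboxylic acid would fare in place of the hydroxymethyl group.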